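Cytotoxicity notes on a triazole thioether series

This account rests on a few compounds, and the source may have more. Where it says the series, first, only, none or still open, it means among the compounds named here.

Measured compounds:
compound 3 `CCSc1nnc(COc2ccccc2C2=NOC(c3ccc(Cl)cc3Cl)C2)n1NC(C)=O` in this assay: 9.7 ug/mL
compound 1 `CCOC(=O)CSc1nnc(COc2ccccc2C2=NOC(c3ccc(Cl)cc3Cl)C2)n1NC(C)=O`: "not determined" (no result reported)
compound 2 `CC(=O)Nn1c(COc2ccccc2C2=NOC(c3ccc(Cl)cc3Cl)C2)nnc1Sc1ccccc1`: "not determined" (no result reported)

For the measured compounds named here, in an ADME assay (MDM cells, Homo sapiens) for cytotoxicity, read by resazurin assay, with a stated time of 3 days (a higher number here means a weaker inhibitor, a lower number a stronger inhibitor), compound 3 gives 9.7 ug/mL, the only number the series shows; compound 1 carries "not determined" (no result reported) and compound 2 carries "not determined" (no result reported), so no step between measured compounds can be set against the scatter. Compound 4 `CSc1nnc(COc2ccccc2C2=NOC(c3ccc(Cl)cc3Cl)C2)n1NC(C)=O` differs from compound 3 by hydrogen in place of methyl on a saturated chain carbon bound to a sulfur. The change removes a single carbon from the ethylsulfanyl group, and with no measured step of this kind in hand, the expectation is a step no larger than the usual scatter, with no clear direction. The estimate for compound 4 is therefore 10 ug/mL, range 4.5 ug/mL to 22 ug/mL, meaning an expected step of a 1.0-fold higher number from compound 3 to compound 4 (0.01 log units; within the scatter).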

Compound 4, half-maximal inhibitory concentration: 2.7 ug/mL
Compound 4: middle estimate off by 3.7-fold (0.57 log units), on the high side; the whole stated range lies above it.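

Shortening ethylsulfanyl to methylsulfanyl is not a silent change in this assay: it gives a 3.6-fold lower number from compound 3 to compound 4 (0.56 log units; beyond the scatter). For the compounds shown here, the saturated chain on the sulfur therefore registers in this read-out, which a single value could not show, though one pair fixes only this one change. No evidence at hand accounts for the step.

Steps involving compound 1 and compound 2 cannot be read, as neither carries a number. On these data alone, whether a longer chain such as propyl, or an amine or carboxylic acid on the chain, would move the value remains open.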